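A few compounds are considered here, and "the series" means these few. Any claim that something is new, unique, unknown or untested is made for them only; others in the source may bear on it.

Measured so far in an assay on CHO cells for displacement of a labelled ligand from sphingosine 1-phosphate receptor 2 (Homo sapiens); on this read-out lower numbers stand for stronger inhibition and higher numbers for weaker inhibition:

Compound 1 `Cc1cc([C@@H]2C[C@H]2C(=O)O)ccc1-c1noc(-c2ccc(OC(C)C)c(C(F)(F)F)c2)n1` — compound 1 gives > 10000 nM, which is a limit of the assay and not a number.
Compound 2 `Cc1nc(CCC(=O)O)ccc1-c1noc(-c2ccc(OC(C)C)c(C#N)c2)n1` — compound 2 gives > 10000 nM, likewise a limit.
Compound 3 `Cc1cc([C@@H]2C[C@H]2C(=O)O)ccc1-c1noc(-c2ccc(OC(C)C)c(C#N)c2)n1` — compound 3 gives > 10000 nM; > 10000 nM; > 10000 nM (3 entries), each entry a limit.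

Compound 1 therefore does not stand at any single number in this assay; its result is a limit, and the other two compounds show the same kind of result, so no ordering among the three can be read from these values (the limit of > 10000 nM in this assay, at which 2 of the 3 values shown sit). Compound 4 `Cc1cc(CC(C)C(=O)O)ccc1-c1noc(-c2ccc(OC(C)C)c(C(F)(F)F)c2)n1` has not yet been measured in this assay. It differs from compound 1 in one place: 2-carboxypropyl in place of 2-carboxycyclopropyl on an aromatic carbon. Among the compounds with values here, no measured step between two compounds exists here to set the size of such a change, so the expectation rests on the three limits alone: the step from compound 1 to compound 4 is expected to be a step that the limit leaves unreadable from compound 1 to compound 4, with no shift beyond the scatter. For compound 4 the expected result in this assay is 15000 nM, within 5000 nM to 50000 nM, most likely again reported only as a limit.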

Compound 4, half-maximal inhibitory concentration: > 10000 nM
Compound 4 ended at the assay's limit; the forecaster's own chance of this, stated with the estimate: 85%; the middle value lies beyond the limit too.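

In this assay compound 4 gives > 10000 nM, a limit of the assay and not a number. Compound 1 also gave only a limit, so no step can be read between compound 1 and compound 4. The compounds shown leave open how 2-carboxypropyl and 2-carboxycyclopropyl compare in this assay, and where any of these compounds would fall as a readable number: the limit of > 10000 nM in this assay, at which 3 of the 4 values shown sit.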